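Swapping a hydroxyethyl chain for cyclopropyl

The compounds below may be only part of what the source reports. "The series", "measured", "known", "first", "only" and "open" are said of these compounds alone.

Compound 2 `OCCc1cc2nn(-c3ccccc3)cc2cn1` was tested in a functional assay on K562 cells (Homo sapiens) for inhibition, read by fluorescence, with a stated time of 72 h; a lower number here means a stronger inhibitor of growth, a higher number a weaker inhibitor of growth. In this assay compound 2 gives > 100000 nM, which is a limit of the assay and not a number. Compound 1 `Cc1nc(CCO)cc2nn(-c3ccccc3)cc12` likewise gives > 100000 nM in this assay, again a limit. Compound 3 `CCCCc1cc2nn(-c3ccccc3)cc2c(C)n1` gives 8500 nM in this assay. The step that the two limits leave unreadable from compound 1 to compound 2 cannot be sized, since both ends sit at the limit of > 100000 nM in this assay, at which 2 of the 3 values shown sit. Among the compounds with values here, the step of an at least 11-fold lower number from compound 1 to compound 3 (1.07 log units; beyond the scatter) is the one readable change, and it removes the hydroxy group from the chain while lengthening it.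

Compound 4 `c1ccc(-n2cc3cnc(C4CC4)cc3n2)cc1` differs from compound 2 in one place: cyclopropyl in place of 2-hydroxyethyl on an aromatic carbon. This change also removes the hydroxy group, together with the chain that carried it, and puts a small carbon ring in its place. The step of an at least 11-fold lower number from compound 1 to compound 3 (1.07 log units; beyond the scatter) therefore bears on it most directly and points downward, although the methyl of compound 3 that compound 4 lacks leaves the comparison imperfect. A downward step an at least 5.0-fold lower number from compound 2 to compound 4 (0.69 log units; beyond the scatter) beyond the scatter is expected from compound 2 to compound 4. Compound 4 is estimated at 20000 nM in this assay, within a range from 4000 nM to 100000 nM.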

Compound 4, concentration for 50% growth inhibition: 60500 nM
Compound 4: middle estimate off by 3.0-fold (0.48 log units), on the low side; the measured number falls inside the stated range.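

Within the data shown here, with cyclopropyl in place of 2-hydroxyethyl on this aromatic carbon, next to the ring nitrogen, the unmethylated core yields a readable number for the first time: in this assay, compound 4 gives 60500 nM. The step is an at least 1.6-fold lower number from compound 2 to compound 4 (0.21 log units; that floor lies within the scatter), so the data show only a floor for this change, and that floor does not lie beyond the scatter; a real drop is possible but is not established by these two compounds. The true size of the step stays unknown because compound 2 carries a limit of the assay and not a number: the limit of > 100000 nM in this assay, at which 2 of the 4 values shown sit.

Compound 4 loses the hydroxy group and gains a three-membered carbon ring in a single step, and the compounds shown do not separate these two parts of the change. As far as these compounds go, it also remains open how a plain ethyl group, a longer alkyl chain such as the butyl of compound 3, or an amine would behave on this same aromatic carbon of the core of compound 2, and whether such a group would bring the number lower than that of compound 4.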